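Fluoro in Place of Hydroxy on the Shared Core

The source may hold more compounds than are shown below. What is called first, only, known or untested is meant among the compounds shown, and "the series" means these compounds.

Compound 2 `O=C(CSc1nnc(-c2ccncc2)n1-c1ccccc1)N/N=C/c1ccc(O)cc1` stands at the weaker end of the two measured compounds in a functional assay on HepG2 cells (Homo sapiens) for inhibition, read by MTT assay, with a stated time of 48 h; on this read-out higher numbers stand for weaker inhibition and lower numbers for stronger inhibition. In this assay compound 2 gives > 50000 nM, which is a limit of the assay and not a number. Compound 1 `O=C(CSc1nnc(-c2ccncc2)n1-c1ccccc1)N/N=C/c1ccc([N+](=O)[O-])cc1` carries the same core; in this assay compound 1 gives 15900 nM. Among the compounds with values here, the only measured step, an at least 3.1-fold higher number from compound 1 to compound 2 (0.49 log units; beyond the scatter), rests on (the limit of > 50000 nM in this assay, at which 1 of the 2 values shown sits). Compound 3 `O=C(CSc1nnc(-c2ccncc2)n1-c1ccccc1)N/N=C/c1ccc(F)cc1` differs from compound 2 by fluoro in place of hydroxy on an aromatic carbon. The measured step concerns a nitro giving way to a hydroxy, not a hydroxy giving way to a fluoro, so it bears on this change only loosely; it shows that the group at this place can move the number by at least a modest amount. The expected step is therefore an at least 1.6-fold lower number from compound 2 to compound 3 (0.22 log units; that floor lies within the scatter), downward in this assay. The estimate for compound 3 is 30000 nM, with a range from 10000 nM to 60000 nM.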

Compound 3, half-maximal inhibitory concentration: 9330 nM
Compound 3: the middle estimate sits 3.2-fold (0.51 log units) above what was measured; the whole stated range lies above it.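

In this assay, fluoro in place of hydroxy brings an at least 5.3-fold lower number from compound 2 to compound 3 (0.72 log units; beyond the scatter), so a second group at this place now parts from the hydroxy by more than the scatter. Fluoro in place of nitro brings a 1.7-fold lower number from compound 1 to compound 3 (0.23 log units; within the scatter), so these two groups cannot be told apart here, and among the three compounds the hydroxy alone stands at the weak end. The size of the hydroxy step is only a floor, since compound 2 is held at a limit of the assay and not at a number: the limit of > 50000 nM in this assay, at which 1 of the 3 values shown sits.

The compounds shown leave open whether an amine or a carboxylic acid at this place would stand with the hydroxy or with the fluoro and the nitro. They also leave open where a methoxy group, which keeps the oxygen of the hydroxy but not its hydrogen, would fall.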